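A few compounds are considered here, and "the series" means these few. Any claim that something is new, unique, unknown or untested is made for them only; others in the source may bear on it.

Going by the values given here, compound 2 `O=C(/C=C/c1ccncc1-c1ccc2cc[nH]c2c1)N1CCOCC1` stands lowest of the two numbers measured so far in an assay on a protein complex for inhibition of CDK8/Cyclin C (Homo sapiens), with a stated time of 1 h, tested at 10 uM (on this read-out higher numbers stand for more inhibition at the one concentration tested (going by the name of the read-out) and lower numbers for less inhibition), where compound 2 gives 102%; the nearest is compound 1 `CCOC(=O)/C=C/c1ccncc1-c1ccc2cc[nH]c2c1`, which in this assay gives 104%. Among the compounds with values here, the only measured step, a number 2 percentage points lower from compound 1 to compound 2 (within the scatter), shows that exchanging the group on the carbonyl carbon left the read-out unchanged within the scatter. Compound 3 `O=C(O)/C=C/c1ccncc1-c1ccc2cc[nH]c2c1` differs from compound 2 by hydroxy in place of morpholin-4-yl on a carbonyl carbon. No measured step covers this change, so the one shown step is a weak guide. For compound 3 a step of a number 12 percentage points lower from compound 2 to compound 3 (beyond the scatter) is expected, with compound 3 estimated at 90%, between 60% and 105%.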

Compound 3, a percentage reported as inhibition, at one concentration (the size of the read-out at that concentration, not a potency): 103%
Beside the measured number, compound 3's estimate is 13 percentage points below it; measured number inside the range.
By their numbers in this assay, from the lowest: compounds 2, 3 and 1 (each within the scatter of the next).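

The read-out of this assay holds with carboxy on the carbonyl carbon, with a number 1 percentage points higher from compound 2 to compound 3 (within the scatter) and a number 1 percentage points lower from compound 1 to compound 3 (within the scatter) as the two steps. At this position, the ethoxy, morpholin-4-yl and hydroxy groups therefore cannot be told apart at the one concentration tested, even though hydroxy is far smaller than morpholin-4-yl and brings a hydrogen-bond donor. Nothing at hand explains this result. Still open, on these data alone, is whether an amine or a longer chain on this carbonyl carbon would shift the read-out. Also open, as far as these compounds go, is whether lower concentrations would separate the three compounds.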